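This account rests on a few compounds, and the source may have more. Where it says the series, first, only, none or still open, it means among the compounds named here.

Of the compounds shown here, three have been measured in a functional assay on HEK293 cells for agonist activity at Glucose-dependent insulinotropic receptor (Homo sapiens), read by cAMP accumulation, with a stated time of 30 min (a lower number here means that less compound is needed, a higher number that more compound is needed for the effect), and a fourth awaits its number. Compound 1 `CC(C)OC(=O)N1CCC(n2ncc3cc(-c4ccc(S(C)(=O)=O)cc4)ncc32)CC1` gives 42 nM. Compound 3 `CCc1cnc(N2CCC(n3ncc4cc(-c5ccc(S(C)(=O)=O)cc5)ncc43)CC2)nc1` carries the same core but differs in one place, described as 5-ethylpyrimidin-2-yl in place of isopropoxycarbonyl on an amine nitrogen in a ring, and this change brings a 3.2-fold lower number from compound 1 to compound 3 (0.51 log units; beyond the scatter). In this assay compound 3 gives 13 nM. Compound 2 `CC(C)OC(=O)N1CCC(n2ncc3cc(-c4cc(F)c(C(=O)NCCO)cc4F)ncc32)CC1` is built on a different core; the difference between the two cores is not broken down here. In this assay compound 2 gives 92 nM, the highest number of the three, so more of it is needed for the effect than of either compound 1 or compound 3.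

Compound 4 `CCc1cnc(N2CCC(n3ncc4cc(-c5cc(F)c(C(=O)NCCO)cc5F)ncc43)CC2)nc1` stands to compound 2 as compound 3 stands to compound 1: the change is 5-ethylpyrimidin-2-yl in place of isopropoxycarbonyl on an amine nitrogen in a ring, made at the same kind of position, so it is the same change seen a second time, now on the other core. Among the compounds with values here, whether it will carry over cannot be known from a single earlier example, and the cores differ in a way that is not counted here; still, the one measured instance is the only guide available. The step from compound 2 to compound 4 is therefore expected to be a 3.2-fold lower number from compound 2 to compound 4 (0.50 log units; beyond the scatter), resting on what the same change did from compound 1 to compound 3. On that basis compound 4 is estimated to give about 29 nM in this assay, with a plausible range from 12 nM to 70 nM.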

Compound 4, half-maximal effective concentration: 15 nM
For compound 4 the middle estimate is 1.9-fold (0.29 log units) above the measured one, within the range that was stated.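

Putting 5-ethylpyrimidin-2-yl in place of isopropoxycarbonyl on an amine nitrogen in a ring lowers the number again in this assay on the second core, with a 6.1-fold lower number from compound 2 to compound 4 (0.79 log units; beyond the scatter) and so less compound needed for the effect. Set side by side, the two steps cannot be told apart in size: the same change on two cores in this assay, a 3.2-fold lower number (0.51 log units; beyond the scatter) from compound 1 to compound 3 and a 6.1-fold lower number (0.79 log units; beyond the scatter) from compound 2 to compound 4, 1.9-fold (0.28 log units) apart, within the scatter of two such steps So on these two cores the change carries over in both direction and size, and the step on the second core should not be read as a truly larger gain, but two matched pairs cannot show that the change would behave the same way on any further core, and they do not explain why it lowers the number.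

The compounds shown leave open how a methyl group or a propyl chain in place of the ethyl on the 5-ethylpyrimidin-2-yl group would fare, and how a tert-butoxycarbonyl group would compare with isopropoxycarbonyl. They also leave open whether the same change would hold on a core carrying a carboxylic acid or an amine in place of the groups seen so far on the aromatic ring.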